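Amide-nitrogen substituent change: compound 2 to compound 3

The source may report more compounds than this note shows. Statements on the series, on what has been measured and on what is new or still open speak of the compounds shown alone.

In a physicochemical assay for solubility (a lower number here means a less soluble compound, a higher number a more soluble compound), compound 2 (`CNC(=O)c1cc(C(=O)NC2CC2)cc2c1OC[C@H]2c1ccccc1`) stands only at a limit, >= 190 ug/mL. Compound 1 (`CNC(=O)c1cc(C(=O)Nc2cnn(C)c2)cc2c1OC[C@H]2c1ccccc1`) also gives only a limit, >= 189 ug/mL. Among the measured compounds shown here, the single measured step, a step that the two limits leave unreadable from compound 1 to compound 2, therefore has no readable size and gives no direction. Compound 3 (`CNC(=O)c1cc(C(=O)NCCC[C@H]2OC[C@H](N)CO2)cc2c1OC[C@H]2c1ccccc1`) differs from compound 2 on the amide-type nitrogen: a group of 10 heavy atoms (7 carbon, 1 nitrogen, 2 oxygen; one six-membered non-aromatic ring with 2 hetero atoms) in place of a group of 3 heavy atoms (3 carbon; one three-membered non-aromatic ring of carbon only), on an amide-type nitrogen. The only anchor for the expectation is the limit of compound 2, >= 190 ug/mL. The expected step is a step that the limit leaves unreadable from compound 2 to compound 3, with none beyond the scatter assumed. Compound 3 is estimated at 195 ug/mL, with an expected range of 120 ug/mL to 320 ug/mL.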

Compound 3, solubility: >= 153 ug/mL
Compound 3 was reported as a limit; the forecaster's own chance of this, stated with the estimate: 70%; the middle value lies beyond the limit too.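

Among the compounds shown here, compound 3, like compound 1 and compound 2, stands only as a limit in this assay, so no step among them can be read. The compounds shown leave open whether the group on the amide-type nitrogen shifts this read-out at all.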